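A few compounds are considered here, and "the series" means these few. Any claim that something is new, unique, unknown or untested is made for them only; others in the source may bear on it.

Compound 1 `COc1ccc(-c2cnc(NC(=O)c3ncc[nH]3)n2C)cc1` was examined in a toxicity assay on THP-1 cells (Homo sapiens) for inhibition (a lower number here means that less compound is tolerated, a higher number that more compound is tolerated), where compound 1 gives > 100000 nM; this is a limit of the assay rather than a number. Two related compounds were examined the same way. Compound 2 `CCCn1c(-c2ccc(OC)cc2)cnc1NC(=O)c1ccc(F)cc1` in this assay gives > 100000 nM, again a limit. Compound 3 `Cn1c(-c2ccc([N+](=O)[O-])cc2)cnc1NC(=O)c1ccc(F)cc1` in this assay gives > 50000 nM, also a limit. Compound 1 thus stands at the limit of > 100000 nM in this assay, at which 2 of the 3 values shown sit. Compound 3 sits at the limit of > 50000 nM in this assay, at which 1 of the 3 values shown sits. Going by the values given here, none of the three compounds yields a measurable number, and no step between two measured compounds that differ in one place is available here.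

Compound 4 `COc1ccc(-c2cnc(NC(=O)c3ccccc3)n2C)cc1` has not yet been measured. It differs from compound 1 by phenyl in place of 1H-imidazol-2-yl on a carbonyl carbon. Because the limit of > 100000 nM in this assay, at which 2 of the 3 values shown sit, and the limit of > 50000 nM in this assay, at which 1 of the 3 values shown sits, are where all three values sit, the measured compounds give no handle on what this change does to the readout. The step of a number no higher from compound 1 to compound 4 (the limit leaves the size open) is therefore expected to amount to no change beyond the scatter. Compound 4 is estimated at 100000 nM in this assay, with a range from 50000 nM to 200000 nM, and the assay is expected most likely to report only a limit once more.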

Compound 4, half-maximal cytotoxic concentration: > 100000 nM
Compound 4 gave a limit, no number; the forecaster's own chance of this, stated with the estimate: 85%; the middle value sits exactly at the limit.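

In this assay, compound 1 and compound 4 each give only a limit of the assay and not a number, and the step between them, phenyl in place of 1H-imidazol-2-yl on a carbonyl carbon, cannot be read. The compounds shown leave open at what concentration any of them would harm these cells, and whether this change shifts that concentration.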